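Ethyl for cyclopropyl on the piperazine of compound 2

This account rests on a few compounds, and the source may have more. Where it says the series, first, only, none or still open, it means among the compounds named here.

Measured so far:
compound 1 `CCN1CCN(c2cccc3c2CN([C@H](CCCNS(=O)(=O)c2c[nH]cn2)c2ccc(OC)c(OC)c2)C3=O)CC1`: 51 nM
compound 2 `COc1ccc([C@@H](CCCN(C)S(=O)(=O)c2cccs2)N2Cc3c(cccc3N3CCN(C4CC4)CC3)C2=O)cc1OC`: 1200 nM

In a functional assay on RMS13 cells for antagonist activity at Urotensin-2 receptor (Homo sapiens), read by FLIPR and calcium flux, with a stated time of 1 h (on this read-out higher numbers stand for weaker inhibition and lower numbers for stronger inhibition), compound 2 gives 1200 nM, the higher of the two numbers; compound 1 gives 51 nM, a gap beyond the usual scatter. Compound 3 `CCN1CCN(c2cccc3c2CN([C@H](CCCN(C)S(=O)(=O)c2cccs2)c2ccc(OC)c(OC)c2)C3=O)CC1` differs from compound 2 by ethyl in place of cyclopropyl on an amine nitrogen in a ring. Going by the values given here, compound 1 also carries the ethyl, yet it differs in other places too, so no single step isolates this change. The step of a 2.0-fold lower number from compound 2 to compound 3 (0.30 log units; within the scatter) is expected to be modest, toward stronger inhibition. Compound 3 is therefore expected to give 600 nM, within 200 nM to 2500 nM.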

Compound 3, half-maximal inhibitory concentration: 88 nM
Compound 3: the middle estimate sits 6.8-fold (0.83 log units) above what was measured; the whole stated range lies above it.
By their numbers in this assay, from the lowest: compounds 1 and 3 (each within the scatter of the next); then compound 2.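

In this assay, changing 4-cyclopropylpiperazin-1-yl to 4-ethylpiperazin-1-yl gives a 14-fold lower number from compound 2 to compound 3 (1.13 log units; beyond the scatter), so this one piperazine substituent alone can shift the read-out strongly. With ethyl on the piperazine in both compounds, methyl((thiophen-2-yl)sulfonyl)amino in place of ((1H-imidazol-4-yl)sulfonyl)amino gives only a 1.7-fold higher number from compound 1 to compound 3 (0.24 log units; within the scatter), so this exchange on the chain leaves the read-out within the usual scatter. Nothing available explains why cyclopropyl and ethyl differ so much. The compounds shown leave open how methyl, isopropyl or a bare hydrogen on that piperazine nitrogen would compare with ethyl.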